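Moving the Acid Group Around the Ring

The compounds below may be only part of what the source reports. "The series", "measured", "known", "first", "only" and "open" are said of these compounds alone.

Compound 1 `Cc1c(OCCCCOc2ccc(C(=O)O)cc2Cl)ccc(C(=O)CC2CCCC2)c1O` gives 237 nM in an assay on HEK293 cells for positive allosteric modulation of metabotropic glutamate receptor 2 (Rattus norvegicus), read by thallium flux, with a stated time of 2.5 min; a lower number here means that less compound is needed, a higher number that more compound is needed for the effect.
Compound 2 `Cc1c(OCCCCOc2ccccc2C(=O)O)ccc(C(=O)CC(C)C)c1O` gives 415 nM in this assay.
Compound 3 `Cc1c(OCCCCOc2ccc(C(=O)O)cc2)ccc(C(=O)CC2CCCC2)c1O` gives 824 nM in this assay.

Compound 3 has the highest number of the three, so it needs the most compound for its effect. Against compound 1 its number is clearly higher, a 3.5-fold higher number from compound 1 to compound 3 (0.54 log units; beyond the scatter), a step beyond the scatter; against compound 2 the gap lies within the scatter, so no order between those two can be claimed.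

Compound 4 `Cc1c(OCCCCOc2ccccc2C(=O)O)ccc(C(=O)CC2CCCC2)c1O` is the next compound to be measured. It keeps the whole shared core of compound 3, and the change is this: 2-carboxyphenyl in place of 4-carboxyphenyl on an oxygen on a saturated carbon. For the measured compounds named here, the one measured step, a 3.5-fold higher number from compound 1 to compound 3 (0.54 log units; beyond the scatter), concerns a different change, the loss of a chloro group, and so does not speak to this one. Compound 2 does carry the 2-carboxyphenyl group, but it also differs from compound 3 in the ketone side chain, so its lower number can only be noted, not assigned to the acid position. The expected direction is therefore uncertain, with a step of modest size at most, a 1.5-fold lower number from compound 3 to compound 4 (0.18 log units; within the scatter). Compound 4 is estimated at 550 nM, within a range from 200 nM to 1500 nM.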

Compound 4, half-maximal effective concentration: 335 nM
Beside the measured number, compound 4's estimate is 1.6-fold (0.22 log units) above it; the measured number falls inside the stated range.
By their numbers in this assay, from the lowest: compounds 1, 4, 2 and 3 (each within the scatter of the next, the first and the last beyond it).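

In this assay the move of the acid group alone gives a 2.5-fold lower number from compound 3 to compound 4 (0.39 log units; beyond the scatter) and so shows that, with the same atoms and the same cyclopentyl side chain, 2-carboxyphenyl and 4-carboxyphenyl on this oxygen can be told apart. Once 2-carboxyphenyl is in place, the ketone side chain makes no readable difference, since cyclopentyl in place of isopropyl gives a 1.2-fold lower number from compound 2 to compound 4 (0.09 log units; within the scatter) and that step stays within the scatter. The comparison with the chlorinated compound gives a 1.4-fold higher number from compound 1 to compound 4 (0.15 log units; within the scatter) and is also within the scatter, so 2-carboxyphenyl and 4-carboxy-2-chlorophenyl cannot be put in any order here, although each carries a number clearly apart from that of compound 3.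

No measurement shown gives a reason why the place of the acid group matters in this way. Still open, as far as these compounds go, is whether a chloro group on the 2-carboxyphenyl ring would shift the number further, and whether an amide could stand in place of the carboxylic acid without the number rising.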